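The compounds below may be only part of what the source reports. "The series", "measured", "known", "first", "only" and "open" are said of these compounds alone.

Compounds measured in a functional assay on B-95-8 cells (Cercopithecidae) with B-95-8 cell line (Saguinus oedipus) as the target; a higher number here means a weaker inhibitor, a lower number a stronger inhibitor:

Compound 1 `CN(C)c1nc(Br)nc2c1ncn2[C@@H]1C[C@@H](O)[C@H](CO)O1` gives > 300 uM in this assay, which is a limit of the assay and not a number.
Compound 2 `Nc1nc(Br)nc2c1ncn2[C@@H]1C[C@@H](O)[C@H](CO)O1` gives 6 uM in this assay.

Compound 2 thus holds the only number shown in this assay; the one other value is a limit. Compound 3 `CNc1nc(Br)nc2c1ncn2[C@@H]1C[C@@H](O)[C@H](CO)O1` differs from compound 2 by methyl in place of hydrogen on a nitrogen on an aromatic ring. Within the data shown here, the one measured step that bears on this is an at least 50-fold lower number from compound 1 to compound 2 (1.69 log units; beyond the scatter), where the fully methylated amine was far weaker. Adding a single methyl is expected to move partway back in that direction, giving a weaker inhibitor. Compound 3 is therefore expected to give 30 uM in this assay, within 8 uM to 150 uM, a step of a 5.0-fold higher number from compound 2 to compound 3 (0.70 log units; beyond the scatter).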

Compound 3, concentration for 50% inhibition: 253 uM
Compound 3: middle estimate off by 8.4-fold (0.93 log units), on the low side; measured number outside the range, above it.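

In this assay, the large loss seen earlier turns out not to need both methyls, since the first one alone accounts for it: a 42-fold higher number from compound 2 to compound 3 (1.62 log units; beyond the scatter). Going from one methyl to two gives no change that can be read: an at least 1.1-fold lower number from compound 1 to compound 3 (0.07 log units; that floor lies within the scatter). Compound 1 stands at a limit, so what its second methyl adds cannot be told: the limit of > 300 uM in this assay, at which 1 of the 3 values shown sits.

The compounds shown leave open whether any larger group on this nitrogen, such as ethyl or acetyl, behaves as methyl does. They also leave open whether the same loss holds with chlorine in place of bromine on the shared core.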